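From compound 2 to compound 4: replacing one aromatic group

The source may hold more compounds than are shown below. What is called first, only, known or untested is meant among the compounds shown, and "the series" means these compounds.

In an ADME assay on L6 cells (Rattus norvegicus) for cytotoxicity, read by resazurin assay, with a stated time of 72 h (on this read-out higher numbers stand for weaker inhibition and lower numbers for stronger inhibition), compound 2 `N#Cc1ccc(C(O)(c2ccc(C(F)(F)F)cc2)c2cccnc2)c(F)c1` gives 56100 nM. Compound 1 `NC(c1ccc(Cl)cc1)(c1cccnc1)c1ccccc1Cl` gives 76000 nM, within the scatter of compound 2, so these two numbers cannot be ranked. Compound 3 `N#Cc1ccc(C(O)(c2ccc(Cl)cc2)c2cccnc2)c(F)c1` gives only a limit of the assay, > 100000 nM.

The next structure, compound 4 `OC(c1ccc(C(F)(F)F)cc1)(c1cccnc1)c1cc2ccccc2s1`, differs from compound 2 in one place: 1-benzothiophen-2-yl in place of 4-cyano-2-fluorophenyl on a saturated chain carbon bound to two aromatic carbons and an oxygen on a saturated carbon. In words, 1-benzothiophen-2-yl stands in place of 4-cyano-2-fluorophenyl.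

Among the measured compounds shown here, only one measured step offers any guide, and it is an indirect one. The step of an at least 1.7-fold higher number from compound 2 to compound 3 (0.25 log units; that floor lies within the scatter) puts chloro in place of trifluoromethyl, a different change at a different place, and its floor lies within the scatter. For the measured compounds named here, no measured step replaces 4-cyano-2-fluorophenyl, so the estimate leans on compound 2 at 56100 nM.

In this assay the expected step is a 1.6-fold lower number from compound 2 to compound 4 (0.20 log units; within the scatter), with no change beyond the scatter anticipated. For compound 4 the estimated value is 35000 nM, with an expected range from 12000 nM to 90000 nM.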

Compound 4, half-maximal inhibitory concentration: 58700 nM
Estimate against measurement, compound 4: 1.7-fold (0.22 log units) below, within the range that was stated.
By their numbers in this assay, from the lowest: compounds 2, 4 and 1 (each within the scatter of the next). At a limit, above all of these: compound 3.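

In this assay, the step from the 4-cyano-2-fluorophenyl group to 1-benzothiophen-2-yl is a 1.0-fold higher number from compound 2 to compound 4 (0.02 log units; within the scatter). The earlier step changed a different group, so this is the only view of this position: here a group with a five-membered and a six-membered aromatic ring, holding sulfur, stands in place of a single six-membered ring carrying a nitrile and a fluorine, with no difference the assay can resolve. This read-out also leaves only a short stretch of higher numbers in which any weakening could be sized: the limit of > 100000 nM in this assay, at which 1 of the 4 values shown sits.

On these data alone, it remains open whether a plain phenyl, or an aromatic ring carrying an amine or a carboxylic acid, at this place would move the number beyond the scatter. Also open, as far as these compounds go, is whether 1-benzothiophen-2-yl would give the same result with chloro in place of trifluoromethyl.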